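This account rests on a few compounds, and the source may have more. Where it says the series, first, only, none or still open, it means among the compounds named here.

Of the compounds shown here, three so far have numbers in a functional assay on K562 cells (Homo sapiens) for cytotoxicity, read by ELISA, with a stated time of 4 days; a higher number here means a weaker inhibitor, a lower number a stronger inhibitor. Compound 1 (`Cc1ccsc1-c1cc(-c2ccco2)cc(-c2ccccc2Cl)n1`) gives 25400 nM, compound 2 (`Cc1ccsc1-c1cc(-c2ccoc2)cc(-c2ccco2)n1`) gives 23300 nM, and compound 3 (`Cc1ccc(-c2cc(-c3ccoc3)cc(-c3ccc(Cl)s3)n2)o1`) gives 12700 nM. Compound 3 lies within the scatter of both compound 1 and compound 2, so the three cannot be ranked. Compound 4 (`Clc1ccc(-c2cc(-c3ccoc3)cc(-c3cccnc3)n2)s1`) carries pyridin-3-yl in place of 5-methylfuran-2-yl on an aromatic carbon, next to the ring nitrogen: pyridin-3-yl in place of 5-methylfuran-2-yl on an aromatic carbon. Within the data shown here, no measured pair differs in one place, so the series offers no direct guide to this change. No shift beyond the scatter is expected in this assay, in either direction. The expected step is a 1.2-fold higher number from compound 3 to compound 4 (0.07 log units; within the scatter). For compound 4 the estimated value is 15000 nM, with an expected range of 6000 nM to 35000 nM.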

Compound 4, half-maximal inhibitory concentration: 18700 nM
Compound 4: middle estimate off by 1.2-fold (0.10 log units), on the low side; measured number inside the range.
By their numbers in this assay, from the lowest: compounds 3, 4, 2 and 1 (each within the scatter of the next).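

In this assay, among these compounds, the first single-place change gives a 1.5-fold higher number from compound 3 to compound 4 (0.17 log units; within the scatter) and so leaves pyridin-3-yl and 5-methylfuran-2-yl indistinguishable on this aromatic carbon, next to the ring nitrogen. For this one pair, a six-membered aromatic ring stands here with no shift beyond the scatter from a five-membered one. No available evidence bears on why the two groups read alike.

Still open, going by these compounds, is whether an amine or a carboxylic acid at this position would move the number beyond the scatter. Also open, on these data alone, is whether this step holds with other groups in place of 5-chlorothiophen-2-yl or furan-3-yl.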